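This account rests on a few compounds, and the source may have more. Where it says the series, first, only, none or still open, it means among the compounds named here.

Two compounds have been assessed in a functional assay on cells (Cancer cell lines, Homo sapiens) for cytotoxicity, read by sulforhodamine B assay, with a stated time of 48 h; on this read-out higher numbers stand for weaker inhibition of growth and lower numbers for stronger inhibition of growth. Compound 1 `COc1ccc(OC)c(-c2cc(-c3ccccc3)nn2-c2ccc(S(N)(=O)=O)cc2)c1` gives 31100 nM in this assay, while compound 2 `Oc1ccc(O)c(-c2cc(-c3ccccc3)nn2-c2ccccc2)c1` gives 71200 nM, the higher of the two numbers, a gap that lies beyond the usual scatter. Compound 3 `NS(=O)(=O)c1ccc(-n2nc(-c3ccccc3)cc2-c2cc(O)ccc2O)cc1` has not yet been measured; it differs from compound 2 by sulfamoyl in place of hydrogen on an aromatic carbon. For the measured compounds named here, no directly comparable step is available, so the expectation rests only on the two values in hand. Compound 3 is expected to land somewhat below compound 2, a step from compound 2 to compound 3 of a 1.6-fold lower number from compound 2 to compound 3 (0.20 log units; within the scatter), with an estimated 45000 nM and a range from 15000 nM to 130000 nM.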

Compound 3, concentration for total growth inhibition: 100000 nM
Compound 3: the middle estimate sits 2.2-fold (0.35 log units) below what was measured; the measured number falls inside the stated range.
By their numbers in this assay, from the lowest: compound 1; then compounds 2 and 3 (each within the scatter of the next).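

In this assay sulfamoyl in place of hydrogen, on an aromatic carbon para to a large group, gives a step that cannot be told from the scatter (a 1.4-fold higher number from compound 2 to compound 3 (0.15 log units; within the scatter)). By contrast, 2,5-dihydroxyphenyl in place of 2,5-dimethoxyphenyl gives a step beyond the scatter, though a modest one (a 3.2-fold higher number from compound 1 to compound 3 (0.51 log units; beyond the scatter)). Nothing available explains either step. From the compounds shown here alone, whether an amine, a carboxylic acid or a methylsulfonyl group at the sulfamoyl position would move the number remains open, as does the effect of a single methoxy group in place of the two hydroxyl groups.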